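The source may hold more compounds than are shown below. What is called first, only, known or untested is meant among the compounds shown, and "the series" means these compounds.

Of the compounds shown here, three sharing one core have been tested in a functional assay on BMMC cells (Mus musculus, strain C57BL/6) for inhibition, with stated times of 5 days and 48 h; a lower number here means a stronger inhibitor, a higher number a weaker inhibitor. Compound 1 `C=C1CC[C@@H]2[C@](C)(CO)[C@H](O)CC[C@@]2(C)[C@@H]1C/C=C1\C=COC1=O` gives 2770 nM. Compound 2 `C=C1CC[C@@H]2[C@](C)(CO)[C@H](O)CC[C@@]2(C)[C@@H]1CC=O` gives only a limit, > 30000 nM, that is the limit of > 30000 nM in this assay, at which 1 of the 3 values shown sits. That replacement produces an at least 10-fold higher number from compound 1 to compound 2 (1.03 log units; beyond the scatter). Compound 3 `C=C1CC[C@@H]2[C@](C)(CNCc3ccc(C)cc3)[C@H](O)CC[C@@]2(C)[C@@H]1/C=C/C1=CCOC1=O` stands lowest of the two numbers in this assay with 740 nM, its nearest neighbour being compound 1, beyond the scatter. Compound 4 `C=C1CC[C@@H]2[C@](C)(CNCc3ccc(F)cc3)[C@H](O)CC[C@@]2(C)[C@@H]1/C=C/C1=CCOC1=O` differs from compound 3 only by fluoro in place of methyl on an aromatic carbon. Going by the values given here, no measured step touches this change; the one step known alters a different part of the core. For compound 4 in this assay a step within the scatter is therefore expected, a 1.1-fold higher number from compound 3 to compound 4 (0.03 log units; within the scatter). Compound 4 is estimated at 800 nM, between 350 nM and 1800 nM.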

Compound 4, half-maximal inhibitory concentration: 350 nM
Estimate against measurement, compound 4: 2.3-fold (0.36 log units) above; the range from low to high includes it.
By their numbers in this assay, from the lowest: compound 4; then compound 3; then compound 1. At a limit, above all of these: compound 2.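

Going by these compounds alone, the aromatic carbon para to a large group, which no earlier step touched, proves responsive in this assay: fluoro in place of methyl gives a modest change beyond the scatter (a 2.1-fold lower number from compound 3 to compound 4 (0.33 log units; beyond the scatter)). So 4-fluorobenzyl serves at least as well as 4-methylbenzyl here, and a swap of a single heavy atom on this ring is enough to move the number. Nothing measured here offers a cause for this step.

Open remains how chloro, methoxy or trifluoromethyl would read at this carbon. Also open, going by these compounds, is whether a plain benzyl group, with hydrogen there, would fall on either side of these two compounds.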